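Swapping methylamino for methyl on a sulfonyl sulfur

The compounds below may be only part of what the source reports. "The series", "measured", "known", "first", "only" and "open" are said of these compounds alone.

Measured compounds:
- compound 1, `CS(=O)(=O)c1cccc(C#Cc2cc(Cl)ccc2OCC(=O)O)c1`: 15 nM
- compound 2, `CNS(=O)(=O)c1ccc(C)c(C#Cc2cc(Cl)ccc2OCC(=O)O)c1`: 10 nM
- compound 3, `CCCS(=O)(=O)c1cccc(C#Cc2c(Cl)cccc2OCC(=O)O)c1`: 55 nM

All three share a core carrying an acetic acid chain, a chlorine and an alkyne that links to a second ring bearing a sulfonyl group. In an assay on CHO cells for displacement of a labelled ligand from prostaglandin D2 receptor 2 (Homo sapiens), read by scintillation counting (on this read-out lower numbers stand for stronger inhibition and higher numbers for weaker inhibition), compound 2 gives 10 nM, the lowest of the three numbers. Compound 1 gives 15 nM in this assay, a number that sits within the usual scatter of that of compound 2, so no order between these two can be claimed. Compound 3 gives 55 nM in this assay, a number beyond the scatter above that of compound 2.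

Compound 4, `Cc1ccc(S(C)(=O)=O)cc1C#Cc1cc(Cl)ccc1OCC(=O)O`, has not yet been measured. It differs from compound 2 in one place: methyl in place of methylamino on a sulfonyl sulfur. Compound 1 already carries a methylsulfonyl group and gives a number within the scatter of compound 2, which suggests that this exchange changes little. The number expected for compound 4 in this assay is therefore close to that of compound 2, with a step of a 1.2-fold higher number from compound 2 to compound 4 (0.08 log units; within the scatter) that is expected to stay within the scatter. The estimated value for compound 4 is 12 nM, with a range from 5 nM to 30 nM.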

Compound 4, inhibition constant: 5 nM
For compound 4 the middle estimate is 2.4-fold (0.38 log units) above the measured one; the range from low to high includes it.
By their numbers in this assay, from the lowest: compounds 4, 2 and 1 (each within the scatter of the next, the first and the last beyond it); then compound 3.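

In this assay, methyl in place of methylamino on a sulfonyl sulfur gives a 2.0-fold lower number from compound 2 to compound 4 (0.30 log units; within the scatter), so the methylamino group and its hydrogen-bond donor can be removed here without a change that stands clear of the scatter. Compound 4 also allows a second one-place comparison: methyl in place of hydrogen on an aromatic carbon gives a 3.0-fold lower number from compound 1 to compound 4 (0.48 log units; beyond the scatter), a modest step, and the only one of these two that lies beyond the scatter. Nothing available here explains either step.

Going by these compounds, it remains open how ethyl or dimethylamino on the sulfonyl sulfur would compare with methyl. On these data alone, it is also open whether a chlorine or a methoxy group could take the place of the new methyl on the aromatic carbon and give a similar number.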